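The source may hold more compounds than are shown below. What is called first, only, known or untested is meant among the compounds shown, and "the series" means these compounds.

Compound 1 `C#Cc1ccc(CCC(=O)O)cc1` is the starting point of this comparison. In a functional assay on 1321-N1 cells for agonist activity at Free fatty acid receptor 1 (Homo sapiens), read by calcium flux, with a stated time of 0.4 s (a lower number here means that less compound is needed, a higher number that more compound is needed for the effect), compound 1 gives only a limit of the assay, > 100000 nM. Among the three compounds with measured values, this one sits at the limit of > 100000 nM in this assay, at which 1 of the 3 values shown sits. Compound 2 `C/C=C\C#Cc1ccc(CCC(=O)O)c(F)c1` gives 47.9 nM in this assay, and compound 3 `CCCCCCCC#Cc1ccc(CCC(=O)O)cc1` gives 1450 nM. Compound 4 `C=C(C)C#Cc1ccc(CCC(=O)O)cc1` has not yet been measured; it differs from compound 1 by 1-methylethenyl in place of hydrogen on a triple-bonded carbon. For the measured compounds named here, no step between two measured compounds is known here, so the move from compound 1 to compound 4 can only be judged from compound 2 and compound 3, which carry other groups on the triple-bonded carbon and both give real numbers. Compound 4 is therefore expected to reach a measurable value, estimated at 300 nM, between 60 nM and 3000 nM. Compound 4 is thus expected to show a step of an at least 330-fold lower number from compound 1 to compound 4 (2.52 log units; beyond the scatter).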

Compound 4, half-maximal effective concentration: 417 nM
Beside the measured number, compound 4's estimate is 1.4-fold (0.14 log units) below it; low and high end bracket the measured number.
By their numbers in this assay, from the lowest: compound 2; then compound 4; then compound 3. At a limit, above all of these: compound 1.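

In this assay, 1-methylethenyl in place of hydrogen on a triple-bonded carbon gives an at least 230-fold lower number from compound 1 to compound 4 (2.37 log units; beyond the scatter). For the compounds shown here, this is the first change read at this place alone, and it shows that 3 heavy atoms with no ring are enough to give a measurable value. The size of the step remains a minimum, as compound 1 stands at a limit of the assay: the limit of > 100000 nM in this assay, at which 1 of the 4 values shown sits.

The compounds shown leave open whether the double bond matters, which a saturated isopropyl group on the same carbon could test. From the compounds shown here alone, how an amine at this place would fare also remains open.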